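The source may report more compounds than this note shows. Statements on the series, on what has been measured and on what is new or still open speak of the compounds shown alone.

Measured in a functional assay on ileum (Cavia porcellus) for inhibition; a lower number here means a stronger inhibitor, a higher number a weaker inhibitor:
- compound 1 `COC(=O)C1=C(C)NC(C)=C(C(=O)OC)C1c1c(-c2ccccn2)nc2sccn12`: 2570 nM
- compound 2 `COC(=O)C1=C(C)NC(C)=C(C(=O)OC)C1c1c(-c2cccnc2)nc2sccn12`: 3550 nM

In this assay compound 2, at 3550 nM, stands within the scatter of compound 1. Compound 3 `COC(=O)C1=C(C)NC(C)=C(C(=O)OC)C1c1c(-c2ccsc2)nc2sccn12` is still unmeasured. The change is thiophen-3-yl in place of pyridin-3-yl on an aromatic carbon. Only a 1.4-fold higher number from compound 1 to compound 2 (0.14 log units; within the scatter) bears on it, pyridin-3-yl in place of pyridin-2-yl, and that step stays within the scatter. Among the measured compounds shown here, no measured compound carries thiophen-3-yl, so the expectation is weakly grounded, and no step beyond the scatter is expected. The estimated step is a 1.4-fold lower number from compound 2 to compound 3 (0.15 log units; within the scatter). For compound 3 the expected value is 2500 nM, with an estimated range of 800 nM to 8000 nM.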

Compound 3, half-maximal inhibitory concentration: 2.3 nM
Estimate against measurement, compound 3: 1100-fold (3.04 log units) above; measured number below the stated range.
By their numbers in this assay, from the lowest: compound 3; then compounds 1 and 2 (each within the scatter of the next).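

In this assay this position proves highly sensitive to the ring it carries: thiophen-3-yl in place of pyridin-3-yl gives a 1500-fold lower number from compound 2 to compound 3 (3.19 log units; beyond the scatter) and in place of pyridin-2-yl gives a 1100-fold lower number from compound 1 to compound 3 (3.05 log units; beyond the scatter) while the two pyridinyl groups had stayed within the scatter of each other. The change swaps a six-membered aromatic ring holding nitrogen for a five-membered one holding sulfur, so ring size and hetero atom move together. Nothing measured independently explains the size of this step. Open, going by these compounds, is whether phenyl, thiophen-2-yl or furan-3-yl would retain this strength, which would separate ring size from the sulfur atom.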